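The source may hold more compounds than are shown below. What is called first, only, known or untested is meant among the compounds shown, and "the series" means these compounds.

Measured in an in vitro functional assay on SH-EP1 cells for agonist activity at Neuronal acetylcholine receptor; alpha4/beta2 (Homo sapiens), read by FLIPR and calcium flux; a lower number here means a smaller maximal response, a higher number a larger maximal response:
Compound 1 `COc1cncc(C2=CC3CC(C2)CN(C)C3)c1`: 15%
Compound 2 `C1=C(c2cncc(Oc3ccccc3)c2)CC2CNCC1C2`: 30%
Compound 3 `CC(C)Oc1cncc(C2=CC3CNCC(C2)C3)c1`: 54%

Compound 3 stands highest of the three, with compound 2 nearest and compound 1 furthest behind. Among the compounds with values here, the one measured step, a number 24 percentage points higher from compound 2 to compound 3 (beyond the scatter), shows that the group on the oxygen matters. Compound 4 `COc1cncc(C2=CC3CNCC(C2)C3)c1` takes the next step: methyl in place of isopropyl on an oxygen on an aromatic ring. Within the data shown here, no measured pair shows exactly this change. Compound 1 also carries a methyl on the oxygen, yet it differs from compound 4 at the ring nitrogen as well, so its value only hints that a methyl may sit lower. Compound 4 is therefore expected at 35%, in a range of 15% to 60%. That would be an expected a number 19 percentage points lower from compound 3 to compound 4 (beyond the scatter).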

Compound 4, largest response reached (reported as percent of maximum), in percent of the reference or control that the assay uses: 100%
Compound 4: middle estimate off by 65 percentage points, on the low side; the whole stated range lies below it.
By their numbers in this assay, from the lowest: compound 1; then compound 2; then compound 3; then compound 4.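

In this assay, methoxy gives a number 46 percentage points higher from compound 3 to compound 4 (beyond the scatter) and also a number 70 percentage points higher from compound 2 to compound 4 (beyond the scatter), so among these three groups on the oxygen, the response climbs from phenyl through isopropyl to methyl. The ring nitrogen also counts: hydrogen in place of methyl there gives a number 85 percentage points higher from compound 1 to compound 4 (beyond the scatter), so the low value of compound 1 does not show that methoxy itself gives a weak response. No available evidence explains either change. Open, from the compounds shown here alone, is whether ethoxy or a hydroxyl on the ring would match methoxy, and whether an ethyl on the ring nitrogen would fall as far as methyl.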